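The compounds below may be only part of what the source reports. "The series", "measured", "known", "first", "only" and "open" are said of these compounds alone.

Compound 3 `CCCN(c1cccc(C(F)(F)F)c1)c1cnc(C(=O)[C@H]2C[C@@H]2C(=O)O)c(OC)c1` stands highest of the three values obtained so far in an assay for inhibition of leukotriene C4 synthase (Homo sapiens), read by LC-MS, with stated times of 15 min and 30 min (on this read-out higher numbers stand for weaker inhibition and lower numbers for stronger inhibition), though its nearest neighbour compound 1 `COc1cc(N(CC2CC2)c2cccc(C(F)(F)F)c2)cnc1C(=O)[C@H]1C[C@@H]1C(=O)O` gives 6.42 nM and compound 2 `COc1cc(N(CC(C)C)c2cccc(C(F)(F)F)c2)cnc1C(=O)[C@H]1C[C@@H]1C(=O)O` gives 4.74 nM, while compound 3 itself gives 7.9 nM. The move to compound 4 `CCN(c1cccc(C(F)(F)F)c1)c1cnc(C(=O)[C@H]2C[C@@H]2C(=O)O)c(OC)c1` is hydrogen in place of methyl on a saturated chain carbon, two bonds along the chain from a nitrogen on an aromatic ring. The measured steps all lie within the scatter: a 1.2-fold higher number from compound 1 to compound 3 (0.09 log units; within the scatter), a 1.4-fold lower number from compound 1 to compound 2 (0.13 log units; within the scatter) and the most related one, a 1.7-fold higher number from compound 2 to compound 3 (0.22 log units; within the scatter), which also shortens the chain on the aromatic nitrogen. Trimming one more carbon is therefore expected to leave this assay essentially unchanged, with at most a slight drift to a higher number, so the step is estimated as a 1.2-fold higher number from compound 3 to compound 4 (0.08 log units; within the scatter). Compound 4 is expected at 9.5 nM, within a range of 4.5 nM to 20 nM.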

Compound 4, half-maximal inhibitory concentration in the leukotriene C4 synthase assay: 13 nM
Compound 4: the middle estimate sits 1.4-fold (0.14 log units) below what was measured; measured number inside the range.
By their numbers in the leukotriene C4 synthase assay, from the lowest: compounds 2, 1, 3 and 4 (each within the scatter of the next, the first and the last beyond it).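

For the compounds shown here, in the leukotriene C4 synthase assay, the short ethyl chain of compound 4 opens gaps that the earlier compounds did not show (a 2.7-fold higher number from compound 2 to compound 4 (0.44 log units; beyond the scatter)) and (a 2.0-fold higher number from compound 1 to compound 4 (0.31 log units; beyond the scatter)), although the direct step from propyl to ethyl stays small (a 1.6-fold higher number from compound 3 to compound 4 (0.22 log units; within the scatter)). The same change also lowers lipophilicity in a physicochemical assay for lipophilicity, read by LC-MS, in phosphate buffer, measured as octanol-water partition, at pH 7.4; on this read-out lower numbers stand for lower lipophilicity and higher numbers for higher lipophilicity: the measured distribution coefficient of compound 3, 1.2, and of compound 4, 0.7, a number 0.50 log units lower (beyond the scatter). In the physicochemical assay compound 3 gives 1.2 and compound 4 gives 0.7.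

A single pair cannot show whether these two shifts are linked. As far as these compounds go, it remains open whether an amine or a carboxylic acid in place of the ethyl, or a longer chain, would keep the number in the leukotriene C4 synthase assay low.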